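The source may hold more compounds than are shown below. What is called first, only, known or untested is meant among the compounds shown, and "the series" means these compounds.

Measured so far:
compound 1 `COc1ccc(-c2cn3ccnc3c(-c3ccc4ncn(C5CCCCC5)c4c3)n2)cc1`: 91.7%
compound 2 `Brc1ccc(-c2cn3ccnc3c(-c3ccc4ncn(C5CCCCC5)c4c3)n2)cc1`: 60.7%

Compound 1 and compound 2 share one core and differ only in the group on the aromatic carbon described below. In a functional assay on SR cells (Homo sapiens) for inhibition, read by sulforhodamine B assay, with a stated time of 48 h, tested at 10 uM (on this read-out lower numbers stand for less inhibition and higher numbers for more inhibition at the one concentration tested (going by the name of the read-out)), compound 1 gives 91.7%, and compound 2 gives 60.7%. For the measured compounds named here, the single measured step is a number 31 percentage points lower from compound 1 to compound 2 (beyond the scatter). Going by the values given here, compound 2 therefore stands lowest of the two numbers, with compound 1 as its only neighbour.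

Compound 3 `c1csc(-c2cn3ccnc3c(-c3ccc4ncn(C5CCCCC5)c4c3)n2)c1` is not yet measured. Its change from compound 2: thiophen-2-yl in place of 4-bromophenyl on an aromatic carbon. Among the compounds with values here, no measured step exchanges a six-membered aromatic ring for a five-membered one, so the only guide is the step from compound 1 to compound 2, which shows that the group at this position can move the read-out by a large amount, in either direction unknown for thiophen-2-yl. For compound 3 the expected step is a number 9.3 percentage points higher from compound 2 to compound 3 (within the scatter), within the scatter. Compound 3 is estimated at 70%, range 40% to 95%.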

Compound 3, a percentage reported as inhibition, at one concentration (the size of the read-out at that concentration, not a potency): 27.2%
Estimate against measurement, compound 3: 42.8 percentage points above, and the stated range ends above it.
By their numbers in this assay, from the lowest: compound 3; then compound 2; then compound 1.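

In this assay the exchange of 4-bromophenyl for thiophen-2-yl gives a number 33.5 percentage points lower from compound 2 to compound 3 (beyond the scatter) on this carbon, and the exchange of 4-methoxyphenyl for thiophen-2-yl gives a number 64.5 percentage points lower from compound 1 to compound 3 (beyond the scatter) on the same carbon. For the compounds shown here, the earlier pair showed only that the read-out moves with the group on a six-membered aromatic ring; now the one compound with a five-membered aromatic ring here, compound 3, stands lowest of the three, with both steps beyond the scatter. Nothing available explains either step.

The compounds shown do not separate the effect of the ring from the loss of the group carried on it, which a plain phenyl group would address. On these data alone, whether the high number of compound 1 depends on its methoxy group remains open, and an amine or a carboxylic acid in that place would test this.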